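This account rests on a few compounds, and the source may have more. Where it says the series, first, only, none or still open, it means among the compounds named here.

Compound 1 `N#CC1=C(N)Oc2c(N)cc3nc4ccccc4nc3c2C12C(=O)N(Cc1cnnn1-c1ccccc1Cl)c1ccccc12` gives > 50000 nM in an ADME assay on L02 cells (Homo sapiens) for antiproliferative activity, read by MTT assay, with a stated time of 48 h (on this read-out higher numbers stand for weaker inhibition and lower numbers for stronger inhibition), a limit of the assay. Compound 2 `CCOc1ccccc1-n1nncc1CN1C(=O)C2(C(C#N)=C(N)Oc3c(N)cc4nc5ccccc5nc4c32)c2ccccc21` gives > 50000 nM in this assay, also a limit.

Compound 2 therefore stands at the limit, as does compound 1: both values sit at the limit of > 50000 nM in this assay, at which 2 of the 2 values shown sit. Within the data shown here, the only measured step, a step that the two limits leave unreadable from compound 1 to compound 2, is unreadable in size. Compound 3 `CCc1cccc(C)c1-n1nncc1CN1C(=O)C2(C(C#N)=C(N)Oc3c(N)cc4nc5ccccc5nc4c32)c2ccccc21` differs from compound 2 by 2-ethyl-6-methylphenyl in place of 2-ethoxyphenyl on an aromatic nitrogen. Among the measured compounds shown here, no measured step bears readably on this change, so no step beyond the scatter can be expected in this assay; the expected step that the limit leaves unreadable from compound 2 to compound 3 rests on nothing readable. Compound 3 is estimated at 70000 nM, range 20000 nM to 300000 nM, most likely reported again as a limit.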

Compound 3, half-maximal inhibitory concentration: > 50000 nM
Compound 3: a limit, no number; the forecaster's own chance of this, stated with the estimate: 85%; the middle value lies beyond the limit too.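

No step among compound 1, compound 2 and compound 3 can be read, as all three share one limit: the limit of > 50000 nM in this assay, at which 3 of the 3 values shown sit.

Still open, on these data alone, is how far each compound lies past that limit, and whether any group on the aromatic nitrogen shifts the value in this assay at all.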